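The source may hold more compounds than are shown below. What is called first, only, known or untested is meant among the compounds shown, and "the series" means these compounds.

The study concerns two compounds measured and a third one not yet measured, all sharing one core. Compound 1 is `COc1ccc(CCOc2ccc(-c3c(C)nc(C)c([C@H](OC(C)(C)C)C(=O)O)c3N3CCC(C)(C)CC3)cc2)cc1`. In a toxicity assay on MT2 cells (Homo sapiens) for cytotoxicity, read by XTT assay, with a stated time of 4 days (on this read-out higher numbers stand for lower toxicity in this test and lower numbers for higher toxicity in this test), compound 1 gives >= 33500 nM, which is a limit of the measurement rather than a number. Compound 2 is `Cc1nc(C)c([C@H](OC(C)(C)C)C(=O)O)c(N2CCC(C)(C)CC2)c1-c1ccc(OC2COCC2c2ccc(F)cc2)cc1`. In this assay compound 2 gives >= 32000 nM; >= 32000 nM (2 entries), again only a limit of the measurement. Among the compounds with values here, compound 1 therefore stands at the limit of >= 33500 nM in this assay, at which 1 of the 2 values shown sits, and no single number is available for it; there is no step between compound 1 and compound 2 to speak of, since both sit at limits.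

The third compound, compound 3, is `Cc1nc(C)c([C@H](OC(C)(C)C)C(=O)O)c(N2CCC(C)(C)CC2)c1-c1ccc(OCCc2cccnc2)cc1`. It differs from compound 1 in one place: pyridin-3-yl in place of 4-methoxyphenyl on a saturated chain carbon, two bonds along the chain from an oxygen on an aromatic ring. Within the data shown here, no measured step accompanies this change, so the expectation rests on the values shown. Compound 1 and compound 2 both reached the limit, and compound 3 is expected to behave alike: the step that the limit leaves unreadable from compound 1 to compound 3 is expected to be none beyond the usual scatter. Compound 3 is accordingly estimated at 40000 nM, within a range from 20000 nM to 100000 nM, most likely reported again only as a limit.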

Compound 3, half-maximal cytotoxic concentration: >= 25000 nM
Compound 3 ended at the assay's limit; the forecaster's own chance of this, stated with the estimate: 85%; the middle value is on the limit's open side.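

Compound 1 and compound 3 both sit at limits in this assay, not at numbers, and no step can be read from pyridin-3-yl in place of 4-methoxyphenyl. The compounds shown leave open at what concentration, if any, compound 1, compound 2 or compound 3 would reach half-maximal cytotoxicity in this assay.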